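Furan-3-yl in place of 1H-pyrrol-2-yl: compound 4

A few compounds are considered here, and "the series" means these few. Any claim that something is new, unique, unknown or untested is made for them only; others in the source may bear on it.

Of the compounds shown here, three have been tested in a functional assay on A2780 cells (Homo sapiens) for inhibition, read by MTT assay, with a stated time of 72 h; on this read-out higher numbers stand for weaker inhibition of growth and lower numbers for stronger inhibition of growth. Compound 1 `N#C/C(=C\c1ccc(Cl)cc1)C(=O)c1ccc[nH]1` gives 35000 nM. Compound 2 `COc1ccc(CNC(=O)/C(C#N)=C/c2ccc[nH]2)cc1` reaches the limit of the assay, > 50000 nM, and not a number. Compound 3 `N#C/C(=C\c1ccc[nH]1)C(=O)NCc1ccc(Cl)c(Cl)c1` likewise ends at the assay limit, > 50000 nM. Going by the values given here, compound 2 thus stands at the limit of > 50000 nM in this assay, at which 2 of the 3 values shown sit, and no step between measured compounds can be drawn from it. The untested compound 4 `COc1ccc(CNC(=O)/C(C#N)=C/c2ccoc2)cc1` differs from compound 2 by furan-3-yl in place of 1H-pyrrol-2-yl on a double-bonded chain carbon bound to a double-bonded chain carbon. Among the compounds with values here, with compound 2 known only as a limit, no measured step gives a direction for this change. The step of a number no higher from compound 2 to compound 4 (the limit leaves the size open) is expected to be none beyond the scatter. Compound 4 is estimated at 50000 nM, within a range from 20000 nM to 120000 nM, and is expected most likely to be reported again only as a limit in this assay.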

Compound 4, concentration for 50% growth inhibition: 6000 nM
For compound 4 the middle estimate is 8.3-fold (0.92 log units) above the measured one, outside the stated range (below it).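

In this assay, going by these compounds alone, furan-3-yl in place of 1H-pyrrol-2-yl gives an at least 8.3-fold lower number from compound 2 to compound 4 (0.92 log units; beyond the scatter), so this place on a double-bonded chain carbon bound to a double-bonded chain carbon does affect the read-out, which the earlier compounds could not show. The swap keeps the heavy-atom count and the five-membered aromatic ring but exchanges a ring hydrogen-bond donor for a ring hydrogen-bond acceptor, and this single pair cannot say which of these differences, if either, matters. The step gives only a minimum size because compound 2 is known only as a limit: the limit of > 50000 nM in this assay, at which 2 of the 4 values shown sit.

On these data alone, whether a thiophen-3-yl or furan-2-yl ring at this place would give a comparable number remains open. As far as these compounds go, it is equally open whether furan-3-yl would produce a similar step on the side chain of compound 3.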